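The source may hold more compounds than are shown below. What is called first, only, known or untested is meant among the compounds shown, and "the series" means these compounds.

Working notes on the sulfonamide series. Three measured compounds share one core and differ only at the sulfonamide nitrogen. Compound 1 `CC[C@@H]1C(=O)N(C)c2cnc(Nc3ccc(S(=O)(=O)NC)cc3)nc2N1C1CCCC1` in a functional assay on K562 cells (Homo sapiens) for antiproliferative activity, read by CCK-8 assay, with a stated time of 72 h (a lower number here means a stronger inhibitor of growth, a higher number a weaker inhibitor of growth), gives 222 nM. Compound 2 `CCCCNS(=O)(=O)c1ccc(Nc2ncc3c(n2)N(C2CCCC2)[C@H](CC)C(=O)N3C)cc1` in this assay gives 412 nM, a step of a 1.9-fold higher number from compound 1 to compound 2 (0.27 log units; within the scatter). Compound 3 `CC[C@@H]1C(=O)N(C)c2cnc(Nc3ccc(S(=O)(=O)Nc4ccccc4)cc3)nc2N1C1CCCC1` in this assay gives 4180 nM, the highest number of the three; the steps of a 19-fold higher number from compound 1 to compound 3 (1.27 log units; beyond the scatter) and a 10-fold higher number from compound 2 to compound 3 (1.01 log units; beyond the scatter) both show that the phenyl on the sulfonamide nitrogen goes with a large rise in the number. Compound 4 `CC[C@@H]1C(=O)N(C)c2cnc(Nc3ccc(S(N)(=O)=O)cc3)nc2N1C1CCCC1` has not yet been measured; relative to compound 3 it carries hydrogen in place of phenyl on a sulfonamide nitrogen. Both measured steps into compound 3 bear on this change: each introduced a phenyl on the sulfonamide nitrogen and raised the number well beyond the scatter, so removing it is expected to lower the number by a similar large amount, returning toward the region of compound 1 and compound 2. In this assay compound 4 is therefore expected at 300 nM, with a range of 120 nM to 800 nM. This corresponds to an expected step of a 14-fold lower number from compound 3 to compound 4 (1.14 log units; beyond the scatter).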

Compound 4, concentration for 50% growth inhibition: 470 nM
Compound 4: middle estimate off by 1.6-fold (0.19 log units), on the low side; the measured number falls inside the stated range.
By their numbers in this assay, from the lowest: compounds 1, 2 and 4 (each within the scatter of the next, the first and the last beyond it); then compound 3.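

In this assay, the step with hydrogen in place of phenyl on the sulfonamide nitrogen (an 8.9-fold lower number from compound 3 to compound 4 (0.95 log units; beyond the scatter)) shows that the high number of compound 3 stands out against the unsubstituted sulfamoyl group as well as against methyl and butyl. Hydrogen and butyl at this nitrogen cannot be told apart (a 1.1-fold higher number from compound 2 to compound 4 (0.06 log units; within the scatter)), while hydrogen against methyl gives a modest step just beyond the scatter (a 2.1-fold higher number from compound 1 to compound 4 (0.33 log units; beyond the scatter)). Across these four compounds, phenyl is thus the one change with a large step, and the number does not follow a simple order from hydrogen through methyl to butyl, since compound 1 alone lies beyond the scatter of compound 4.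

As far as these compounds go, it remains open whether a benzyl or cyclohexyl group on this nitrogen would go with compound 3 or with the other three, and how a chain ending in an amine or a carboxylic acid would read. Nothing available here accounts for why compound 3 stands apart.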